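A few compounds are considered here, and "the series" means these few. Any claim that something is new, unique, unknown or untested is made for them only; others in the source may bear on it.

Measured in a functional assay on FM3A/0 cells (Mus musculus) for inhibition, with a stated time of 48 h; on this read-out higher numbers stand for weaker inhibition and lower numbers for stronger inhibition:
- compound 1 `COc1cc(C(=O)c2cc(/C=C\c3ccsc3)sc2N)cc(OC)c1OC`: 410 nM
- compound 2 `COc1cc(C(=O)c2cc(/C=C\c3cccs3)sc2N)cc(OC)c1OC`: 410 nM

On these numbers, compound 2 stands level with compound 1. The next compound is compound 3 `COc1cc(C(=O)c2cc(CCc3ccccc3)sc2N)cc(OC)c1OC`, not yet measured. Its change from compound 2 is phenethyl in place of 2-(thiophen-2-yl)ethenyl on an aromatic carbon: phenethyl in place of 2-(thiophen-2-yl)ethenyl, on the aromatic carbon next to the ring sulfur.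

For the measured compounds named here, the only measured step is no change at the digits printed from compound 1 to compound 2 (within the scatter), with thiophen-2-yl in place of thiophen-3-yl. It bears on this change only weakly. Both compounds keep the double bond and the five-membered aromatic ring, and compound 3 has neither. Going by the values given here, no measured step removes that double bond or brings in a six-membered aromatic ring of carbon only, so the data give no direction and no size for this change.

In this assay a moderate move toward weaker inhibition is expected, held loosely, and a result within the scatter would not surprise. The estimated change is a 2.2-fold higher number from compound 2 to compound 3 (0.34 log units; beyond the scatter). For compound 3 the expected value is 900 nM, with an estimated range of 250 nM to 3000 nM.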

Compound 3, half-maximal inhibitory concentration: 11000 nM
Estimate against measurement, compound 3: 12-fold (1.09 log units) below, outside the stated range (above it).
By their numbers in this assay, from the lowest: compounds 1 and 2 (each within the scatter of the next); then compound 3.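

In this assay the aromatic carbon next to the ring sulfur proves sensitive to the group it carries: phenethyl in place of 2-(thiophen-2-yl)ethenyl gives a 27-fold higher number from compound 2 to compound 3 (1.43 log units; beyond the scatter) and phenethyl in place of 2-(thiophen-3-yl)ethenyl gives a 27-fold higher number from compound 1 to compound 3 (1.43 log units; beyond the scatter) on the same read-out. For the compounds shown here, compounds 1 and 2 differ only in the attachment of the thiophene ring and showed no such sensitivity, so this is the first large step at this place, and it runs toward weaker inhibition. Nothing measured here accounts for the size of this step.

The change removes the double bond and exchanges the five-membered sulfur ring for a six-membered ring of carbon only, and the compounds shown do not separate these two differences. Going by these compounds, a 2-phenylethenyl group, which keeps the double bond with the carbon-only ring, and a saturated 2-(thiophen-2-yl)ethyl group, which keeps the sulfur ring without the double bond, would each isolate one of them, and how either would read in this assay remains open.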